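Swapping Nitro for Benzothiazole on a Shared Core

The source may hold more compounds than are shown below. What is called first, only, known or untested is meant among the compounds shown, and "the series" means these compounds.

Compound 1 `CC1(C)OC(=O)C(=CNc2ccccc2[N+](=O)[O-])C(=O)O1` was examined in an ADME assay on MT4 cells (Homo sapiens) for cytotoxicity, read by MTT assay, with a stated time of 4 days; a higher number here means that more compound is tolerated, a lower number that less compound is tolerated. In this assay compound 1 shows only a limit, >= 411000 nM, not a measured number. Compound 2 `O=c1cc[nH]c2c([N+](=O)[O-])cccc12` likewise gives only a limit in this assay, > 71600 nM. So compound 1 stands at a limit, and no finished number anchors it.

Compound 3 `CC1(C)OC(=O)C(=CNc2ccccc2-c2nc3ccccc3s2)C(=O)O1` differs from compound 1 in one place: 1,3-benzothiazol-2-yl in place of nitro on an aromatic carbon. Among the measured compounds shown here, no step between measured compounds exists to size this change, so the expectation rests on compound 1 alone. The step of an at least 3.4-fold lower number from compound 1 to compound 3 (0.53 log units; beyond the scatter) is expected to run toward less tolerance, beyond the scatter. For compound 3 the estimated value is 120000 nM, with a range from 25000 nM to 411000 nM.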

Compound 3, half-maximal cytotoxic concentration: 41600 nM
Compound 3: the middle estimate sits 2.9-fold (0.46 log units) above what was measured; measured number inside the range.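

In this assay the exchange of nitro for 1,3-benzothiazol-2-yl runs as an at least 9.8-fold lower number from compound 1 to compound 3 (0.99 log units; beyond the scatter) and gives the shared core its first finished number. Among the compounds shown here, the earlier compounds offered only limits, so this is the first sign that a change on this aromatic carbon, ortho to a large group, can move the read-out. The step is a minimum, and its full size stays unknown since compound 1 gives only a limit: the limit of >= 411000 nM in this assay, at which 1 of the 3 values shown sits.

Going by these compounds, whether other groups at this place would lower the number as far remains open. An amine, a carboxylic acid or a short alkyl chain here would show whether the effect is particular to 1,3-benzothiazol-2-yl.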